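A sulfonyl group on the piperazine ring of compound 2

The source may report more compounds than this note shows. Statements on the series, on what has been measured and on what is new or still open speak of the compounds shown alone.

In a functional assay on NB1 cells (Homo sapiens) for cytotoxicity, read by MTT assay, with a stated time of 3 days (a lower number here means a stronger inhibitor, a higher number a weaker inhibitor), compound 1 `CNc1nc(SCc2nc3ccccc3[nH]2)nc(-c2ccccc2)c1C#N` gives 4.46 nM and compound 2 `N#Cc1c(-c2ccccc2)nc(SCc2nc3ccccc3[nH]2)nc1N1CCNCC1` gives 6.75 nM. Going by the values given here, these two values lie within the scatter of each other, so compound 2 stands level with the only other compound measured. Among the compounds with values here, the one measured step is a 1.5-fold higher number from compound 1 to compound 2 (0.18 log units; within the scatter), with piperazin-1-yl in place of methylamino on an aromatic carbon.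

Compound 3 `N#Cc1c(-c2ccccc2)nc(SCc2nc3ccccc3[nH]2)nc1N1CCN(S(=O)(=O)c2ccccc2[N+](=O)[O-])CC1` has (2-nitrophenyl)sulfonyl in place of hydrogen on an amine nitrogen in a ring. Within the data shown here, no measured compound carries any substituent on that nitrogen, so the step to compound 2, a 1.5-fold higher number from compound 1 to compound 2 (0.18 log units; within the scatter), is only a loose guide. No shift beyond the scatter is expected, though the uncertainty is wide in both directions. The estimated step is a 1.3-fold higher number from compound 2 to compound 3 (0.12 log units; within the scatter). For compound 3 the estimate is 9 nM, with an expected range from 2.5 nM to 35 nM.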

Compound 3, half-maximal inhibitory concentration: 2.5 nM
Compound 3: middle estimate off by 3.6-fold (0.56 log units), on the high side; measured number inside the range.
By their numbers in this assay, from the lowest: compounds 3, 1 and 2 (each within the scatter of the next, the first and the last beyond it).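

In this assay, the amine nitrogen in the ring of compound 2 accepts a substituent of 12 heavy atoms with no loss: (2-nitrophenyl)sulfonyl in place of hydrogen gives a 2.7-fold lower number from compound 2 to compound 3 (0.43 log units; beyond the scatter), a modest step. Going by these compounds alone, the earlier compounds showed only a swap of piperazin-1-yl for methylamino within the scatter, whereas this is the first step that lies beyond it, and it shows that the free ring nitrogen is not required for a low number. Nothing available here speaks to the reason for this step.

Within the data shown here, the single compound does not separate the sulfonyl link, the phenyl ring and the nitro group from one another. An acetyl or benzoyl group on the same nitrogen, or an amine in place of the nitro group, would bear on that question.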